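The source may hold more compounds than are shown below. What is called first, only, known or untested is meant among the compounds shown, and "the series" means these compounds.

Working notes on the series of three compounds tested in an assay on isolated protein for inhibition of DNA topoisomerase 1 (Homo sapiens), with a stated time of 30 min, tested at 100 uM; a lower number here means a weaker effect, a higher number a stronger effect of the compound at the concentration tested.

Compound 1 `Oc1ccc(-c2cc(-c3cccs3)cc(-c3ccccc3O)n2)cc1` gives 72.2% in this assay. Among the measured compounds shown here, compound 2 `Oc1ccc(-c2cc(-c3ccoc3)cc(-c3ccccc3O)n2)cc1` gives 30.1%; the step of a number 42.1 percentage points lower from compound 1 to compound 2 (beyond the scatter) is the only single-point change measured so far. Compound 3 `Oc1ccccc1-c1cc(-c2cccnc2)cc(-c2ccccc2O)n1` gives 66.4%. On the numbers shown, compound 3 stands with compound 1, the two being within the scatter of each other, and clearly apart from compound 2, which lies beyond the scatter below it.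

Compound 4 `Oc1ccc(-c2cc(-c3cccnc3)cc(-c3ccccc3O)n2)cc1` has not yet been measured in this assay. It differs from compound 3 by 4-hydroxyphenyl in place of 2-hydroxyphenyl on an aromatic carbon, so the two have the same atoms joined differently. For the measured compounds named here, no measured step covers this exchange: the step from compound 1 to compound 2 concerns the five-membered ring at the other position and tells nothing about which hydroxyphenyl sits next to the ring nitrogen. Compounds 1 and 2 carry the same pair of hydroxyphenyl groups as compound 4, but with different five-membered rings, so only compound 3 is a direct neighbour of compound 4. The expectation is therefore a step of a number 4.4 percentage points lower from compound 3 to compound 4 (within the scatter) of no clear size beyond the scatter. For compound 4 the estimate is 62%, within a range from 40% to 80%.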

Compound 4, a percentage reported as inhibition, at one concentration (the size of the read-out at that concentration, not a potency): 1.5%
Estimate against measurement, compound 4: 60.5 percentage points above; measured number outside the range, below it.
By their numbers in this assay, from the lowest: compound 4; then compound 2; then compounds 3 and 1 (each within the scatter of the next).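

In this assay, the place on the aromatic carbon next to the ring nitrogen proves highly sensitive to how the same atoms are joined: exchanging 2-hydroxyphenyl for 4-hydroxyphenyl gives a large fall (a number 64.9 percentage points lower from compound 3 to compound 4 (beyond the scatter)), so this position matters at least as much as the one probed by the earlier step. With the pair of hydroxyphenyl groups held fixed, pyridin-3-yl also emerges as the poorest of the three rings at the other position, both against furan-3-yl (a number 28.6 percentage points lower from compound 2 to compound 4 (beyond the scatter)) and against thiophen-2-yl (a number 70.7 percentage points lower from compound 1 to compound 4 (beyond the scatter)), and compound 4 is the weakest of the series. Nothing at hand bears on the cause of these steps.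

On these data alone, it remains open whether the exchange of 2-hydroxyphenyl for 4-hydroxyphenyl has a similar size with thiophen-2-yl or furan-3-yl at the other position, as only the pyridin-3-yl pair covers it. Also open, as far as these compounds go, is how 3-hydroxyphenyl, a methoxyphenyl or an aminophenyl group would read at the same place.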